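The source may hold more compounds than are shown below. What is called first, only, known or untested is meant among the compounds shown, and "the series" means these compounds.

Measured compounds in an assay on CHO-K1 cells for displacement of a labelled ligand from adenosine receptor A1 (Homo sapiens), read by scintillation counting, with a stated time of 60 min; on this read-out higher numbers stand for weaker inhibition and lower numbers for stronger inhibition:
compound 1 `Nc1nc(N/N=C/c2ccc(Br)cn2)nc2c1ncn2[C@@H]1O[C@H](CO)[C@@H](O)[C@H]1O`: 4.7 nM
compound 2 `CSCC/C=N/Nc1nc(N)c2ncn([C@@H]3O[C@H](CO)[C@@H](O)[C@H]3O)c2n1`: a limit, > 10000 nM
compound 3 `Nc1nc(N/N=C/c2ccc(OCc3ccc(F)cc3)cc2)nc2c1ncn2[C@@H]1O[C@H](CO)[C@@H](O)[C@H]1O`: 70 nM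

Compound 3 gives the highest of the two numbers shown; compound 1 sits nearest, with a lower number, and the value of compound 2 is a limit of the assay (the limit of > 10000 nM in this assay, at which 1 of the 3 values shown sits). Among the measured compounds shown here, the single measured step, an at least 2100-fold higher number from compound 1 to compound 2 (3.32 log units; beyond the scatter), changes the group on the carbon doubly bonded to nitrogen, so it bears only loosely on the present change. Compound 4 `CC(=O)Nc1ccc(/C=N/Nc2nc(N)c3ncn([C@@H]4O[C@H](CO)[C@@H](O)[C@H]4O)c3n2)cc1` differs from compound 3 by acetamido in place of (4-fluorobenzyl)oxy on an aromatic carbon. Since compound 1, carrying a small aryl group, gives 4.7 nM, a moderate shift toward lower numbers is expected for compound 4, a 2.0-fold lower number from compound 3 to compound 4 (0.30 log units; within the scatter). Compound 4 is therefore estimated at 35 nM, between 10 nM and 150 nM.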

Compound 4, inhibition constant: > 10000 nM
Compound 4 ended at the assay's limit; the forecaster's own chance of this, stated with the estimate: 5%; at least 280-fold (2.45 log units) between middle value and limit.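

Acetamido in place of (4-fluorobenzyl)oxy on this aromatic carbon, para to a large group, brings an at least 140-fold higher number from compound 3 to compound 4 (2.15 log units; beyond the scatter) here, so this position is far less forgiving than compound 3 alone could show. 4-Acetamidophenyl in place of 5-bromopyridin-2-yl brings an at least 2100-fold higher number from compound 1 to compound 4 (3.32 log units; beyond the scatter) as well, so an aryl group on the carbon with a double bond to nitrogen does not by itself give a low number. The value of compound 4 is a limit, and the step from compound 2 cannot be read: the limit of > 10000 nM in this assay, at which 2 of the 4 values shown sit.

On these data alone, whether a methoxy group or an amine on this aromatic carbon would return the number to the range of compound 3 remains open.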